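Ester to acid: from compound 2 to compound 4

The compounds below may be only part of what the source reports. "The series", "measured", "known", "first", "only" and "open" are said of these compounds alone.

Three compounds of the shared core have numbers in a functional assay on Ramos cells (Homo sapiens) for antiproliferative activity, read by CCK-8 assay, with a stated time of 72 h, tested at 40 uM; on this read-out higher numbers stand for more inhibition at the one concentration tested (going by the name of the read-out) and lower numbers for less inhibition. Compound 1 `CCOC(=O)c1sc(-c2cccc(NC(=O)c3ccc(C(F)(F)F)cc3)c2)nc1Nc1ccc(N2CCN(C)CC2)cc1` gives 18.4%. Compound 2 `CCOC(=O)c1sc(-c2cccc(NC(=O)c3ccc(Cl)cc3)c2)nc1Nc1ccc(N2CCN(C)CC2)cc1` gives 46.9%. Compound 3 `CCOC(=O)c1sc(-c2cccc(NC(=O)c3ccc(F)c(Cl)c3)c2)nc1Nc1ccc(N2CCN(C)CC2)cc1` gives 72.5%. Compound 2 thus holds the second highest of the three numbers: a number 28.5 percentage points higher from compound 1 to compound 2 (beyond the scatter), while a number 25.6 percentage points higher from compound 2 to compound 3 (beyond the scatter) and a number 54.1 percentage points higher from compound 1 to compound 3 (beyond the scatter). All three measured steps change the aryl group on the carbonyl carbon of the amide and leave the ethoxycarbonyl untouched.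

Compound 4 `CN1CCN(c2ccc(Nc3nc(-c4cccc(NC(=O)c5ccc(Cl)cc5)c4)sc3C(=O)O)cc2)CC1` differs from compound 2 in one place: hydrogen in place of ethyl on an oxygen next to a carbonyl group, that is, ethoxycarbonyl to carboxy. Among the compounds with values here, no measured step bears on this position, so the three steps give no direct guide to the size or direction of the change on the ester. The expected step is estimated as a number 11.9 percentage points lower from compound 2 to compound 4 (beyond the scatter), an estimate carried with wide uncertainty. The starting point is the number of compound 2, and without any step on the ester the estimate rests on that number alone.

Compound 4 is expected to give about 35% in this assay, within a range from 8% to 62%.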

Compound 4, a percentage reported as inhibition, at one concentration (the size of the read-out at that concentration, not a potency): 71.6%
Estimate against measurement, compound 4: 36.6 percentage points below, and the stated range ends below it.
By their numbers in this assay, from the lowest: compound 1; then compound 2; then compounds 4 and 3 (each within the scatter of the next).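

In this assay, the ester position of the shared core proves able to move the read-out: a number 24.7 percentage points higher from compound 2 to compound 4 (beyond the scatter). Until now, every measured step lay on the aryl group on the carbonyl carbon of the amide, and this step shows that a change on the far side of the molecule, ethoxycarbonyl to carboxy, can also matter, at least with the 4-chlorophenyl amide. With this amide, the ethyl on the oxygen next to the carbonyl group is not required for inhibition at the one concentration tested, and nothing measured here accounts for the step.

On these data alone, whether ethoxycarbonyl to carboxy gives a step of similar size and the same direction with the 4-(trifluoromethyl)phenyl or 3-chloro-4-fluorophenyl amide remains open: the carboxy form appears here only with the 4-chlorophenyl amide. A methyl ester, a longer chain such as a propyl ester, or a primary amide at this position would show whether the step follows from losing the ethyl or depends on the free carboxylic acid.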